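From Ketone to Sulfonamide on the Shared Core

This account rests on a few compounds, and the source may have more. Where it says the series, first, only, none or still open, it means among the compounds named here.

Measured compounds:
compound 1 `CC1(C)Oc2ccc(C(=O)c3ccccc3)cc2[C@@H](/N=C(\NC#N)Nc2ccc(Cl)cc2)[C@@H]1O`, 7100 nM
compound 2 `CC(C)(C)C(=O)c1ccc2c(c1)[C@@H](/N=C(\NC#N)Nc1ccc(Cl)cc1)[C@H](O)C(C)(C)O2`, 5400 nM

Two compounds share a core and differ only in the group carried on the carbonyl carbon. In a functional assay (aorta) with Rattus norvegicus as the target (on this read-out higher numbers stand for weaker inhibition and lower numbers for stronger inhibition), compound 1 gives 7100 nM, and compound 2 gives 5400 nM. Among the measured compounds shown here, the single measured step, a 1.3-fold lower number from compound 1 to compound 2 (0.12 log units; within the scatter), is the only comparison available, and it does not separate the two compounds. Compound 2 therefore has the lower of the two numbers, but by a margin that carries no weight.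

Compound 3 `CCN(CC)S(=O)(=O)c1ccc2c(c1)[C@@H](/N=C(\NC#N)Nc1ccc(Cl)cc1)[C@H](O)C(C)(C)O2` is built from compound 2 by diethylsulfamoyl in place of (tert-butyl)carbonyl on an aromatic carbon. For the measured compounds named here, no measured step exchanges the carbonyl-bearing group for a sulfamoyl group, so nothing in the data speaks directly to this change. Going by the values given here, the one step that touches the same position, a 1.3-fold lower number from compound 1 to compound 2 (0.12 log units; within the scatter), shows that swapping the group on the carbonyl carbon left the read-out essentially unchanged.

The expected step is therefore a 1.1-fold lower number from compound 2 to compound 3 (0.03 log units; within the scatter), that is, none beyond the scatter, though the wider range reflects that the change is larger than anything measured. Compound 3 is estimated at 5000 nM, with a range from 1200 nM to 25000 nM.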

Compound 3, half-maximal inhibitory concentration: 1100 nM
For compound 3 the middle estimate is 4.5-fold (0.66 log units) above the measured one; the measured number lies below the stated range.
By their numbers in this assay, from the lowest: compound 3; then compounds 2 and 1 (each within the scatter of the next).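

In this assay, the aromatic carbon that is meta to a fused ring and para to a fused ring proves responsive to the kind of group it carries: diethylsulfamoyl in place of (tert-butyl)carbonyl gives a 4.9-fold lower number from compound 2 to compound 3 (0.69 log units; beyond the scatter), and diethylsulfamoyl in place of benzoyl gives a 6.5-fold lower number from compound 1 to compound 3 (0.81 log units; beyond the scatter). Among the compounds shown here, the earlier pair could not show this, since changing only the group on the carbonyl carbon gave a 1.3-fold lower number from compound 1 to compound 2 (0.12 log units; within the scatter), so the first step beyond the scatter appears when the carbonyl-bearing group is exchanged for a sulfamoyl group, and compound 3 stands apart from both ketones. No measurement at hand accounts for this difference.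

With a single sulfamoyl group among the compounds shown, the step cannot be assigned to the sulfonyl unit or to the two ethyl chains on its nitrogen. Going by these compounds, the plain sulfamoyl group with an unsubstituted nitrogen, dimethylsulfamoyl and diethylcarbamoyl, which keeps the diethylamino part on a carbonyl, would each bear on that question, and how far the step extends on this position remains open.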